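Swapping the ester-bearing side chain for a shorter hydroxyalkenyl

The source may hold more compounds than are shown below. What is called first, only, known or untested is meant among the compounds shown, and "the series" means these compounds.

Among the compounds with values here, compound 2 `COC(=O)/C=C/[C@H]1OCCC[C@@H]1O[Si](C)(C)C(C)(C)C` is one of two compounds measured in a functional assay on MCF7S cells (Homo sapiens) for inhibition (on this read-out higher numbers stand for weaker inhibition of growth and lower numbers for stronger inhibition of growth), where compound 2 gives 80000 nM. Within the data shown here, its only measured neighbour is compound 1 `CC(C)(C)[Si](C)(C)O[C@H]1CCCO[C@@H]1C/C=C/CO`, which in this assay gives 83000 nM; the step of a 1.0-fold lower number from compound 1 to compound 2 (0.02 log units; within the scatter) thus shows no separation beyond the scatter, so compound 2 cannot be set apart from compound 1. The new compound 3 `CC(C)(C)[Si](C)(C)O[C@H]1CCCO[C@@H]1/C=C\CO` differs from compound 2 in one place: 3-hydroxyprop-1-en-1-yl in place of 2-(methoxycarbonyl)ethenyl on a saturated ring carbon. Among the measured compounds shown here, the only measured step that bears on this change is the one from compound 1 to compound 2, in which a hydroxyalkenyl side chain was exchanged for the ester-bearing chain with no movement beyond the scatter. Reversing that kind of exchange is therefore expected to leave this assay essentially unchanged, that is no change at the digits printed from compound 2 to compound 3 (within the scatter). For compound 3 the expected value in this assay is 80000 nM, with a range from 40000 nM to 160000 nM.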

Compound 3, concentration for total growth inhibition: 23000 nM
Estimate against measurement, compound 3: 3.5-fold (0.54 log units) above; measured number outside the range, below it.
By their numbers in this assay, from the lowest: compound 3; then compounds 2 and 1 (each within the scatter of the next).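

In this assay, the side chain on this saturated ring carbon does affect the read-out: 3-hydroxyprop-1-en-1-yl in place of 2-(methoxycarbonyl)ethenyl gives a 3.5-fold lower number from compound 2 to compound 3 (0.54 log units; beyond the scatter), and in place of 4-hydroxybut-2-en-1-yl it gives a 3.6-fold lower number from compound 1 to compound 3 (0.56 log units; beyond the scatter), both modest steps beyond the scatter. The earlier pair showed no such separation, and a hydroxyl-ended chain alone does not go with the lower number, since compound 1 also carries one yet stays within the scatter of compound 2. No measurement here explains the difference between these chains.

The compounds shown leave open whether the lower number of compound 3 would hold with an amine or a carboxylic acid in place of its terminal hydroxyl. They also leave open how a saturated three-carbon chain would compare at this position.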